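The source may hold more compounds than are shown below. What is called first, only, known or untested is meant among the compounds shown, and "the series" means these compounds.

Measured so far:
compound 1, `Fc1ccccc1CSc1nnc(-c2cnccn2)o1`, in a functional assay on SW 1116 cells (Homo sapiens) for antiproliferative activity, read by MTT assay, with a stated time of 48 h; on this read-out lower numbers stand for stronger inhibition and higher numbers for weaker inhibition: 16800 nM
compound 2, `Clc1ccccc1CSc1nnc(-c2cnccn2)o1`, in this assay: 15100 nM
compound 3, `Fc1ccc(CSc2nnc(-c3cnccn3)s2)cc1`, in this assay: 17100 nM

Compound 1 and compound 2 share one core; compound 3 and the unmeasured compound 4, `Clc1ccc(CSc2nnc(-c3cnccn3)s2)cc1`, share another. How the core of compound 3 differs from that of compound 1 is not broken down here. Within the first pair, compound 2 differs from compound 1 by chloro in place of fluoro on an aromatic carbon, and in this assay that change gave a 1.1-fold lower number from compound 1 to compound 2 (0.05 log units; within the scatter). Compound 3 stands with its own value close to compound 1, the two numbers lying within the scatter of each other.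

Compound 4 differs from compound 3 by chloro in place of fluoro on an aromatic carbon. For the measured compounds named here, this is the same kind of change as the one from compound 1 to compound 2, though the place is not the same: in the first pair the carbon is ortho to a large group, in the second it is para to a large group.

Because a 1.1-fold lower number from compound 1 to compound 2 (0.05 log units; within the scatter) lay within the scatter, the expectation for compound 4 is a step of similar size, a 1.1-fold lower number from compound 3 to compound 4 (0.04 log units; within the scatter), in this assay. That rests on a single measured pair on a different core, so the range is kept wide. Compound 4 is therefore estimated at 15500 nM, expected to fall between 9000 nM and 28000 nM.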

Compound 4, half-maximal inhibitory concentration: 4770 nM
Estimate against measurement, compound 4: 3.2-fold (0.51 log units) above; measured number below the stated range.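

In this assay, chloro in place of fluoro on an aromatic carbon, para to a large group, gave a 3.6-fold lower number from compound 3 to compound 4 (0.55 log units; beyond the scatter), so on the core of compound 3 the change has a modest but readable effect. Set beside the earlier pair, the change did not carry over with the same size from one core to the other: the same change on two cores in this assay, a 1.1-fold lower number (0.05 log units; within the scatter) from compound 1 to compound 2 and a 3.6-fold lower number (0.55 log units; beyond the scatter) from compound 3 to compound 4, 3.2-fold (0.51 log units) apart, beyond the scatter of two such steps
For the compounds shown here, this does not show what sets the two steps apart, as the pairs differ both in the core and in where the halogen sits on the ring, and the data cannot separate the two; with only two pairs, it also gives no general rule for this change across the series.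

The compounds shown carry only fluoro or chloro on the aromatic ring, which leaves open whether a bromo, methyl or methoxy group in the same place would follow the step seen with chloro on the core of compound 3. From the compounds shown here alone, it also remains open how the change behaves when both cores carry the halogen at the same place on the ring, which is the comparison that would tell the role of the core from the role of the place.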